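Carbonyl series: aryl amine swap at the shared core

This account rests on a few compounds, and the source may have more. Where it says the series, first, only, none or still open, it means among the compounds named here.

Measured so far in a functional assay on NCI-H1975 cells (Homo sapiens) for inhibition, read by sulforhodamine B assay, tested at 10 uM; a higher number here means more inhibition at the concentration tested (going by the name of the read-out), a lower number less inhibition:
compound 1 `CN1CCN(c2ccc(C3=NNC(c4ccc(N(C)C)cc4)C3)cc2)CC1`: 2.4%
compound 2 `CN1CCN(c2ccc(C3=NN(C(=O)c4ccc(F)cc4)C(c4ccc(N(C)C)cc4)C3)cc2)CC1`: 32.2%
compound 3 `CN1CCN(c2ccc(C3=NN(S(=O)(=O)c4ccc(F)cc4)C(c4ccc(N(C)C)cc4)C3)cc2)CC1`: 95.7%

In this assay compound 2 stands second highest of the three numbers; the steps of a number 29.8 percentage points higher from compound 1 to compound 2 (beyond the scatter) and a number 63.5 percentage points higher from compound 2 to compound 3 (beyond the scatter) fix its place, with a number 93.3 percentage points higher from compound 1 to compound 3 (beyond the scatter) spanning the set.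

Compound 4 `CN(C)c1ccc(C2CC(c3ccc(-n4ccnc4)cc3)=NN2C(=O)c2ccc(F)cc2)cc1` differs from compound 2 in one place: 1H-imidazol-1-yl in place of 4-methylpiperazin-1-yl on an aromatic carbon. Within the data shown here, no measured step covers this change; all three recorded steps concern the group on the amine nitrogen in the ring and leave the 4-methylpiperazin-1-yl group in place. With nothing to go on, the expected step is none beyond the scatter, a number 0.2 percentage points lower from compound 2 to compound 4 (within the scatter). For compound 4 the estimate is 32%, within a range of 10% to 60%.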

Compound 4, a percentage reported as inhibition, at one concentration (the size of the read-out at that concentration, not a potency): -3.5%
Estimate against measurement, compound 4: 35.5 percentage points above; the whole stated range lies above it.
By their numbers in this assay, from the lowest: compounds 4 and 1 (each within the scatter of the next); then compound 2; then compound 3.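

In this assay 1H-imidazol-1-yl in place of 4-methylpiperazin-1-yl gives a number 35.7 percentage points lower from compound 2 to compound 4 (beyond the scatter) in the carbonyl series. Among these compounds, the earlier steps all concerned the group on the ring nitrogen, so this is the first sign that the group on the aromatic carbon also moves the read-out, and by a large step. No measurement at hand accounts for this drop.

From the compounds shown here alone, whether 1H-imidazol-1-yl costs as much alongside the (4-fluorophenyl)sulfonyl group of compound 3 stays open. So does what a morpholin-4-yl group would give on the same aromatic carbon.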